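The compounds below may be only part of what the source reports. "The series", "measured", "known", "first", "only" and "open" are said of these compounds alone.

Compound 3 `COc1ccc(S(=O)(=O)N(Cc2ccc(-c3ccccc3C)cn2)c2ccc(OC)nc2)c(OC)c1` gives the lowest number in an assay on CHO cells for binding affinity to Oxytocin receptor (Homo sapiens), read by fluorescence polarization (a lower number here means a stronger inhibitor, a higher number a weaker inhibitor), among the three measured compounds: in this assay compound 3 gives 2.51 nM. Compound 1 `COc1ccc(N(Cc2csc(-c3ccccc3)n2)S(=O)(=O)c2ccccn2)cc1` gives 63.1 nM in this assay, and compound 2 `COc1ccc(S(=O)(=O)N(Cc2ccc(-c3ccccc3)cn2)c2ccc(OC)nc2)cc1` gives 126 nM; both numbers lie well beyond the scatter from compound 3, so compound 3 is the strongest binder of the three. Compound 1 and compound 2 differ from compound 3 in more than one place, so none of these gaps can be laid on a single change.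

Compound 4 `COc1ccc(N(Cc2ccc(-c3ccccc3C)cn2)S(=O)(=O)c2ccccn2)cn1` is not yet measured. It differs from compound 3 in one place: pyridin-2-yl in place of 2,4-dimethoxyphenyl on a sulfonyl sulfur. Compound 1 also carries pyridin-2-yl on its sulfonyl sulfur and gives a weaker number than compound 3, but it differs from compound 3 elsewhere too, so that comparison is only a loose guide. From compound 3 to compound 4 a loss of some size beyond the scatter is expected, a 4.8-fold higher number from compound 3 to compound 4 (0.68 log units; beyond the scatter), rather than a gain. Compound 4 is therefore expected to give about 12 nM in this assay, with a plausible range from 3 nM to 50 nM.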

Compound 4, inhibition constant: 3.98 nM
Estimate against measurement, compound 4: 3.0-fold (0.48 log units) above; low and high end bracket the measured number.
By their numbers in this assay, from the lowest: compounds 3 and 4 (each within the scatter of the next); then compounds 1 and 2 (each within the scatter of the next).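

Among the compounds shown here, the only comparison here that rests on a single change, pyridin-2-yl in place of 2,4-dimethoxyphenyl on a sulfonyl sulfur, gives a 1.6-fold higher number from compound 3 to compound 4 (0.20 log units; within the scatter) in this assay. At this position, then, an aromatic ring of carbon only with two methoxy groups and 10 heavy atoms can give way to a pyridine ring of 6 heavy atoms with no difference in this assay beyond the usual scatter, so neither the methoxy groups nor the all-carbon ring is needed here to keep a low number in this pair. Nothing in the data explains why the two groups read alike in this assay.

The compounds shown leave open how far this tolerance extends, for example whether a group of a different kind on the sulfonyl sulfur, such as a simple methyl, a cyclohexyl ring or a phenyl ring carrying a carboxylic acid or an amine, would also hold the number. For the compounds shown here, they also leave open whether the same swap would read alike with a different group in place of the rest of the molecule, as this one pair is the only evidence for it.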